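The compounds below may be only part of what the source reports. "The series", "measured", "known", "first", "only" and "open" are said of these compounds alone.

In a functional assay on HEL cells (Homo sapiens) for inhibition (a higher number here means a weaker inhibitor, a lower number a stronger inhibitor), three compounds built on a shared core have been measured. Compound 1 (`CC(C)c1cc(-c2n[nH]c(=O)n2-c2cccc(NC(=O)CCCCCC(=O)NO)c2)c(O)cc1O`) gives 1600 nM. Compound 2 (`CC(C)c1cc(-c2n[nH]c(=O)n2-c2cccc(C(=O)NCCCCCCC(=O)NO)c2)c(O)cc1O`) gives 4600 nM, and compound 3 (`CC(C)c1cc(-c2n[nH]c(=O)n2-c2ccc(C(=O)NCCCCCCC(=O)NO)cc2)c(O)cc1O`) gives 4600 nM. Compound 3 therefore stands level with compound 2 at the top of these three numbers, while compound 1 lies below them by more than the scatter.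

Compound 4 (`CC(C)c1cc(-c2n[nH]c(=O)n2-c2ccc(C(=O)NCCCCC(=O)NO)cc2)c(O)cc1O`) departs from compound 3 in one place: hydroxycarbamoyl in place of 2-(hydroxycarbamoyl)ethyl on a saturated chain carbon, four bonds along the chain from an amide-type nitrogen. In words, hydroxycarbamoyl stands in place of 2-(hydroxycarbamoyl)ethyl on a saturated chain carbon, four bonds along the chain from an amide-type nitrogen. Within the data shown here, no measured pair of compounds isolates this change, so the data offer no direct guide to its size. Only a small move toward a higher number, one that probably stays within the scatter, is expected. The expected step is a 1.3-fold higher number from compound 3 to compound 4 (0.12 log units; within the scatter). For compound 4 the estimated value is 6000 nM, with an expected range of 2500 nM to 15000 nM.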

Compound 4, half-maximal inhibitory concentration: 4600 nM
For compound 4 the middle estimate is 1.3-fold (0.12 log units) above the measured one, and the stated range covers the measured number.
By their numbers in this assay, from the lowest: compound 1; then compounds 2, 3 and 4 (each within the scatter of the next).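

In this assay, hydroxycarbamoyl in place of 2-(hydroxycarbamoyl)ethyl on a saturated chain carbon, four bonds along the chain from an amide-type nitrogen, gives no change at the digits printed from compound 3 to compound 4 (within the scatter) and so leaves the number within the scatter. Among these compounds, this is the first measured pair to isolate a change at this position, and it shows that, on this core and in this amide orientation, going from 5-(hydroxycarbamoyl)pentyl to 3-(hydroxycarbamoyl)propyl does not move the value beyond the scatter. Nothing measured here gives a reason for this result.

From the compounds shown here alone, whether a longer chain than 5-(hydroxycarbamoyl)pentyl would also leave the number in place stays open. So does the outcome of a carboxylic acid in place of the hydroxycarbamoyl end, or of the same shortening on the reversed amide of compound 1.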